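Removing one bromine from a dibromo salicylanilide: cytotoxicity outlook

The source may report more compounds than this note shows. Statements on the series, on what has been measured and on what is new or still open speak of the compounds shown alone.

Measured compounds:
Compound 1, `O=C(Nc1ccc(Sc2nc3ccccc3s2)cc1)c1cc(Br)cc(Br)c1O`, 66000 nM in an ADME assay on HEK293 cells (Homo sapiens) for cytotoxicity, read by reporter gene assay and resazurin assay, with a stated time of 48 h; a higher number here means that more compound is tolerated, a lower number that less compound is tolerated
Compound 2, `COc1c(Br)cc(Br)cc1C(=O)Nc1ccccc1`, > 100000 nM in this assay

For the measured compounds named here, compound 1 is the only compound here with a measured number in this assay; it gives 66000 nM. Compound 2 gives > 100000 nM, which is a limit of the assay rather than a number, (the limit of > 100000 nM in this assay, at which 1 of the 2 values shown sits). Compound 1 and compound 2 differ in more than one place, so their two values can only be set side by side: one sits at a number, the other at the limit.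

Compound 3, `O=C(Nc1ccc(Sc2nc3ccccc3s2)cc1)c1cc(Br)ccc1O`, has not yet been measured. It differs from compound 1 by hydrogen in place of bromo on an aromatic carbon. Going by the values given here, no measured pair here shows what such a change does in this assay, so the size of the step is open. The expectation is a small shift, if any, toward more compound being tolerated, a step of roughly a 1.3-fold higher number from compound 1 to compound 3 (0.11 log units; within the scatter) that may well stay within the scatter. Compound 3 is therefore estimated at 85000 nM, with a likely range from 40000 nM to 180000 nM.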

Compound 3, half-maximal cytotoxic concentration: 42000 nM
Beside the measured number, compound 3's estimate is 2.0-fold (0.31 log units) above it; the measured number falls inside the stated range.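

For the compounds shown here, this is the first measured pair here that differs in only one place: on an aromatic carbon ortho to a hydroxy group, hydrogen stands in place of bromo, turning 3,5-dibromo-2-hydroxyphenyl into 5-bromo-2-hydroxyphenyl. In this assay this change gives a 1.6-fold lower number from compound 1 to compound 3 (0.20 log units; within the scatter) and so cannot be told apart from the ordinary variation between repeated measurements. At this position, then, the bromo can be removed with no clear effect on how much compound the cells tolerate, and nothing shown here bears on why the two values lie so close.

On these data alone, a single pair says little about other replacements, so it remains open whether a chlorine, a methyl group or an amine on the same carbon would also leave the value in the same region. Also open, as far as these compounds go, is whether removing the remaining bromo as well would keep the value there, or whether the same change would behave alike on a different core.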